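This account rests on a few compounds, and the source may have more. Where it says the series, first, only, none or still open, it means among the compounds named here.

Compounds measured so far:
compound 1 `CCN1CCN(CCCN(C[C@H]2Cc3ccccc3CN2)[C@H]2CCCc3cccnc32)CC1` — 33 nM
compound 2 `c1cnc2c(c1)CN[C@H](CN(CCCN1CCNCC1)[C@H]1CCCc3cccnc31)C2` — 2640 nM

In a functional assay on CCRF-CEM cells for antagonist activity at C-X-C chemokine receptor type 4 (Homo sapiens), read by calcium flux, with stated times of 25 min and 90 s (on this read-out higher numbers stand for weaker inhibition and lower numbers for stronger inhibition), compound 1 gives 33 nM and compound 2 gives 2640 nM. Compound 2 stands at the higher of the two numbers, and its distance from compound 1 lies beyond the scatter of repeated runs, so compound 2 is the weaker inhibitor of the pair.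

Compound 3 `c1cnc(CN(CCCN2CCNCC2)[C@H]2CCCc3cccnc32)nc1` has not been measured. It differs from compound 2 in one place: a group of 6 heavy atoms (4 carbon, 2 nitrogen; one six-membered aromatic ring with 2 hetero atoms) in place of a group of 10 heavy atoms (8 carbon, 2 nitrogen; one six-membered non-aromatic ring with 1 hetero atom, one six-membered aromatic ring with 1 hetero atom), on a saturated chain carbon bound to an amine nitrogen. For the measured compounds named here, no directly comparable step between measured compounds is available, so the expectation for compound 3 rests on the values of compound 2 and compound 1 alone. The larger group is given up for a smaller one, and compound 2 already sits at a high number; a further move upward, of modest size, is expected, as the step of a 2.3-fold higher number from compound 2 to compound 3 (0.36 log units; beyond the scatter) shows. For compound 3 the estimate in this assay is 6000 nM, within a range of 1500 nM to 25000 nM.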

Compound 3, half-maximal inhibitory concentration: 4320 nM
For compound 3 the middle estimate is 1.4-fold (0.14 log units) above the measured one, and the stated range covers the measured number.
By their numbers in this assay, from the lowest: compound 1; then compounds 2 and 3 (each within the scatter of the next).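

In this assay the step of a 1.6-fold higher number from compound 2 to compound 3 (0.21 log units; within the scatter) lies within the scatter of repeated runs, so at this place, on a saturated chain carbon bound to an amine nitrogen, the read-out does not separate pyrimidin-2-yl from the larger group it replaces. Pyrimidin-2-yl has no non-aromatic ring and no hydrogen-bond donor, and giving up both parts of the larger group leaves the number within that scatter. No measurement at hand bears on why these two groups read alike.

What the compounds shown leave open is whether any group at this place would give a clearly different number in this assay than these two do. A plain phenyl ring, a benzyl group or a primary amine on a longer chain would test this, and none of them stands among the compounds shown.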